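A few compounds are considered here, and "the series" means these few. Any claim that something is new, unique, unknown or untested is made for them only; others in the source may bear on it.

Measured compounds in a functional assay on P388 cells (Mus musculus) for antiproliferative activity; a lower number here means a stronger inhibitor, a higher number a weaker inhibitor:
compound 1, `N#Cc1c[nH]c2c(NS(=O)(=O)c3ccc(N)cc3)cccc12`, gives 0.72 ug/mL
compound 2, `CS(=O)(=O)Nc1ccc(S(=O)(=O)Nc2cccc3c(C#N)c[nH]c23)cc1`, gives 3.5 ug/mL
compound 3, `Nc1ccc(S(=O)(=O)Nc2cccc3c(Cl)c[nH]c23)cc1`, gives 0.81 ug/mL

Compound 4, `CS(=O)(=O)Nc1ccc(S(=O)(=O)Nc2cccc3c(Cl)c[nH]c23)cc1`, has not yet been measured in this assay. Compound 4 is built from compound 3 by one change, (methylsulfonyl in place of hydrogen on a nitrogen on an aromatic ring), which is the same change that turns compound 1 into compound 2, (methylsulfonyl in place of hydrogen on a nitrogen on an aromatic ring); the surroundings of the changed nitrogen read the same in both cases, so the two changes are the same. In the measured pair that change gave a 4.9-fold higher number from compound 1 to compound 2 (0.69 log units; beyond the scatter). The cores of the two pairs differ only in one place, (chloro in place of cyano on an aromatic carbon), and that difference made a 1.1-fold higher number from compound 1 to compound 3 (0.05 log units; within the scatter), so compound 1 and compound 3 cannot be told apart in this assay.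

For compound 4 the only anchor is the measured pair, and with the cores sitting so close together there is nothing in hand to argue that the change should land differently. The step from compound 3 to compound 4 is therefore expected to be about a 4.9-fold higher number from compound 3 to compound 4 (0.69 log units; beyond the scatter), resting on compound 1 and compound 2 and the step of a 4.9-fold higher number from compound 1 to compound 2 (0.69 log units; beyond the scatter). On that basis compound 4 is estimated at 4 ug/mL in this assay, with a plausible range from 1.6 ug/mL to 10 ug/mL given that a single measured pair is a thin basis and the scatter of the method is appreciable.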

Compound 4, half-maximal inhibitory concentration: 1.6 ug/mL
The estimate for compound 4 lay 2.5-fold (0.40 log units) above the measured number, and the stated range covers the measured number.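

In this assay, methylsulfonyl in place of hydrogen on a nitrogen on an aromatic ring gave a 2.0-fold higher number from compound 3 to compound 4 (0.30 log units; within the scatter) on the chloro core, so on this core the step stays inside the noise of the method, while on the cyano core it had cleared it; even so, the two steps cannot be told apart: the same change on two cores in this assay, a 4.9-fold higher number (0.69 log units; beyond the scatter) from compound 1 to compound 2 and a 2.0-fold higher number (0.30 log units; within the scatter) from compound 3 to compound 4, 2.5-fold (0.39 log units) apart, within the scatter of two such steps

Read the other way round, chloro in place of cyano made little difference with the free amino group, and with the methanesulfonamido group present it gave a 2.2-fold lower number from compound 2 to compound 4 (0.34 log units; beyond the scatter), a modest step, yet this contrast does not separate the two cores either: the same change on two cores in this assay, a 1.1-fold higher number (0.05 log units; within the scatter) from compound 1 to compound 3 and a 2.2-fold lower number (0.34 log units; beyond the scatter) from compound 2 to compound 4, 2.5-fold (0.39 log units) apart, within the scatter of two such steps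

So the change carries across these cores in the same direction and to a size compatible with a single shared step, but two pairs in one assay cannot show that the step is truly constant, nor exclude a modest dependence on the core.

The compounds shown leave open how an acetyl or an ethylsulfonyl on that nitrogen would read in this assay. They also leave open whether a bromo or a methyl in place of chloro and cyano would keep the steps alike.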